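The compounds below may be only part of what the source reports. "The series", "measured", "known", "first", "only" and "open" are said of these compounds alone.

In an ADME assay (liver) for metabolic stability, with Liver microsome (Homo sapiens) as the target, read by LC-MS, using microsomes, with a stated time of 30 min, tested at 1 uM (a higher number here means faster removal of the compound, a lower number slower removal), compound 1 `N#Cc1ccccc1NC(=O)N1CCc2ccccc2[C@H]1c1ccc(C(F)(F)F)cc1` gives 90 mL.min-1.g-1 as a measured number. Compound 2 `O=C(Nc1ccc(F)cc1)N1CCc2cccnc2[C@H]1c1ccc(C(F)(F)F)cc1` gives < 14 mL.min-1.g-1 in this assay and this is a limit of the assay, not a number. Compound 2 therefore stands at the limit of < 14 mL.min-1.g-1 in this assay, at which 1 of the 2 values shown sits, and no exact value is available for it. Among the measured compounds shown here, no step between measured compounds is available to size the change that follows.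

Compound 3 `O=C(Nc1cccnc1)N1CCc2cccnc2[C@H]1c1ccc(C(F)(F)F)cc1` differs from compound 2 by pyridin-3-yl in place of 4-fluorophenyl on an amide-type nitrogen on the shared core, with pyridin-3-yl in place of 4-fluorophenyl on an amide-type nitrogen. The estimated change a step that the limit leaves unreadable from compound 2 to compound 3 is expected to stay within the usual scatter, with no direction foreseen. Compound 3 is expected to read 12 mL.min-1.g-1 in this assay with an estimated range from 7 mL.min-1.g-1 to 25 mL.min-1.g-1.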

Compound 3, intrinsic clearance in microsomes: 104 mL.min-1.g-1
The estimate for compound 3 lay 8.7-fold (0.94 log units) below the measured number; measured number outside the range, above it.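

In this assay, the group on the amide-type nitrogen matters: pyridin-3-yl in place of 4-fluorophenyl gives an at least 7.4-fold higher number from compound 2 to compound 3 (0.87 log units; beyond the scatter). Among the compounds shown here, this is the first readable step, and it shows that, with the shared core unchanged, this single exchange is enough to move the read-out beyond the scatter. Its true size stays unknown, since compound 2 stands at a limit of the assay and not at a number: the limit of < 14 mL.min-1.g-1 in this assay, at which 1 of the 3 values shown sits.

Still open, as far as these compounds go, is whether the step follows the pyridine ring nitrogen that enters or the fluorine that leaves; a plain phenyl on the same amide-type nitrogen would separate the two. Compound 1 differs from compound 3 in more than one place, so it cannot size this change.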